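The source may report more compounds than this note shows. Statements on the series, on what has been measured and on what is new or still open speak of the compounds shown alone.

Measured in an in vitro ADME assay on microsomes from liver (Homo sapiens) for metabolic stability; a lower number here means slower removal, a higher number faster removal of the compound:
- Compound 1 `CC(C)NC(=O)[C@H]1CC[C@@H](n2/c(=N/C(=O)c3ccccc3)[nH]c3ccc(CN4CCCCC4)cc32)CC1`: 203 mL.min-1.g-1
- Compound 2 `CC(C)NC(=O)[C@H]1CC[C@@H](n2/c(=N/C(=O)c3cc(F)cc(Cl)c3)[nH]c3ccc(CN4CCC(C(C)(C)O)CC4)cc32)CC1`: 83 mL.min-1.g-1
- Compound 3 `C=CCNS(=O)(=O)c1cccc(C(=O)/N=c2\[nH]c3cc(CN4CCCCC4)ccc3n2[C@H]2CC[C@@H](CO)CC2)c1`: 100 mL.min-1.g-1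

Compound 2 and compound 3 lie within the usual scatter of each other, while compound 1 gives a higher number than compound 2, a gap beyond the scatter. Compound 4 `CC(C)NC(=O)[C@H]1CC[C@@H](n2/c(=N/C(=O)c3ccncc3)[nH]c3ccc(CN4CCC(C(C)(C)O)CC4)cc32)CC1` is compound 2 with a single change: pyridin-4-yl in place of 3-chloro-5-fluorophenyl on a carbonyl carbon. Among the measured compounds shown here, no two measured compounds differ in one place, so no measured step guides this expectation, and it remains a cautious judgement. The expected step is a 1.8-fold lower number from compound 2 to compound 4 (0.27 log units; within the scatter), towards a lower number in this assay and not clearly beyond the scatter. For compound 4 the estimate is 45 mL.min-1.g-1, with an expected range of 18 mL.min-1.g-1 to 105 mL.min-1.g-1.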

Compound 4, intrinsic clearance in microsomes: 57 mL.min-1.g-1
For compound 4 the middle estimate is 1.3-fold (0.10 log units) below the measured one; the measured number falls inside the stated range.
By their numbers in this assay, from the lowest: compounds 4, 2 and 3 (each within the scatter of the next); then compound 1.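

Among the compounds shown here, this is the first pair here that differs in one place, so a change on this carbonyl carbon can be read directly. In this assay putting pyridin-4-yl in place of 3-chloro-5-fluorophenyl gives a 1.5-fold lower number from compound 2 to compound 4 (0.16 log units; within the scatter) and so swaps a ring of carbon only for one with a hetero atom without a clear shift. Nothing measured here accounts for this result.

Going by these compounds, whether cyclohexyl or a longer alkyl chain on this carbonyl carbon would move the number beyond the scatter stays open. So does whether the same swap behaves alike with a different group on the shared core.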